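Capping the phenol of compound 1 with 4-fluorobenzyl

This account rests on a few compounds, and the source may have more. Where it says the series, first, only, none or still open, it means among the compounds named here.

Values in a functional assay on cells (T-cell, Mus musculus, strain BALB/c) for inhibition, read by MTT assay, with stated times of 24 h and 72 h; on this read-out higher numbers stand for weaker inhibition and lower numbers for stronger inhibition:
compound 1, `COc1cc(-c2nnc(SCc3ccc(F)cc3)o2)ccc1O`, gives 8190 nM
compound 2, `COc1cc(-c2nnc(SCc3ccccc3Cl)o2)ccc1O`, gives 8430 nM
compound 3, `COc1cc(-c2nnc(SCc3ccccc3C)o2)ccc1O`, gives 8420 nM

Compound 1 holds the lowest of the three numbers in this assay, but its steps to the others, a 1.0-fold higher number from compound 1 to compound 2 (0.01 log units; within the scatter) and a 1.0-fold higher number from compound 1 to compound 3 (0.01 log units; within the scatter), sit within the scatter, as does a 1.0-fold lower number from compound 2 to compound 3 (0.00 log units; within the scatter), so no order among the three can be read. Compound 4, `COc1cc(-c2nnc(SCc3ccc(F)cc3)o2)ccc1OCc1ccc(F)cc1`, differs from compound 1 in one place: 4-fluorobenzyl in place of hydrogen on an oxygen on an aromatic ring. Among the compounds with values here, none of the measured steps touches this oxygen; all three vary the benzyl group on the sulfur and none moves the number beyond the scatter. Within the data shown here, the effect of replacing the hydrogen on the aromatic oxygen is therefore undetermined by the series so far, and the estimate for compound 4 rests on compound 1 alone. Compound 4 is expected to give about 10000 nM in this assay, with a range of 3000 nM to 35000 nM, which corresponds to an expected step of a 1.2-fold higher number from compound 1 to compound 4 (0.09 log units; within the scatter).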

Compound 4, half-maximal inhibitory concentration: 12900 nM
For compound 4 the middle estimate is 1.3-fold (0.11 log units) below the measured one; measured number inside the range.
By their numbers in this assay, from the lowest: compounds 1, 3, 2 and 4 (each within the scatter of the next).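

In this assay, within the data shown here, compound 4 is the only compound that varies the aromatic oxygen, and hydroxy to (4-fluorobenzyl)oxy gives a 1.6-fold higher number from compound 1 to compound 4 (0.20 log units; within the scatter). Among these compounds, the earlier steps varied only the benzyl group on the sulfur, so this is the first reading at the oxygen. Within this series, the hydrogen on that oxygen can therefore be replaced by a group carrying a six-membered aromatic ring without a step beyond the scatter. Nothing available bears on why the number responds in this way at this oxygen.

Open, from the compounds shown here alone, is whether a small methyl, a longer chain ending in an amine, or a carboxylic acid on this oxygen would stay within the scatter of compound 1. Also open, going by these compounds, is whether 4-fluorobenzyl on the oxygen behaves the same with 2-chlorobenzyl or 2-methylbenzyl on the sulfur.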